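Chloro for fluoro on the aryl of compound 3

This account rests on a few compounds, and the source may have more. Where it says the series, first, only, none or still open, it means among the compounds named here.

Of the compounds shown here, three share one core and have been measured in a functional assay on CHO cells for agonist activity at adenosine receptor A1 (Homo sapiens), read by fluorescence and ERK phosphorylation, with stated times of 30 min and 1.5 h, tested at 10 uM; on this read-out lower numbers stand for a weaker effect and higher numbers for a stronger effect at the one concentration tested. Compound 1 `Nc1scc(-c2ccc(Cl)cc2)c1C(=O)c1ccccc1` gives 51%, compound 2 `Nc1scc(-c2cccc(F)c2)c1C(=O)c1ccc(Cl)cc1` gives 90%, and compound 3 `Nc1scc(-c2ccc(F)cc2)c1C(=O)c1ccc(Cl)cc1` gives 61%. Going by the values given here, on these numbers compound 3 stands second of the three: its value and that of compound 1 lie within the scatter of each other, while compound 2 stands above it, the step of a number 29 percentage points lower from compound 2 to compound 3 (beyond the scatter) being the only single change measured so far and concerning the fluoro position rather than the halogen itself.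

Compound 4 `Nc1scc(-c2ccc(Cl)cc2)c1C(=O)c1ccc(Cl)cc1` differs from compound 3 by chloro in place of fluoro on an aromatic carbon. Among the compounds with values here, no measured pair isolates this change; compound 1 and compound 3 differ in two places at once, and their two values sit within the scatter. Within the data shown here, with no step bearing directly on the exchange, compound 4 is expected to stay close to compound 3, the estimated step of a number 1 percentage points lower from compound 3 to compound 4 (within the scatter) being small in either direction. Compound 4 is therefore estimated at 60%, within 40% to 82%.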

Compound 4, a percentage reported as activity, at one concentration (the size of the read-out at that concentration, not a potency): 50%
Compound 4: the middle estimate sits 10 percentage points above what was measured; measured number inside the range.
By their numbers in this assay, from the lowest: compounds 4, 1 and 3 (each within the scatter of the next, the first and the last beyond it); then compound 2.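

Chloro in place of fluoro now has a measured step of its own in this assay, and a number 11 percentage points lower from compound 3 to compound 4 (beyond the scatter) shows that the halogen at this place, para to a large group, does change the read-out, though only modestly. Chloro in place of hydrogen on an aromatic carbon gives a number 1 percentage points lower from compound 1 to compound 4 (within the scatter) and so leaves no difference to read between these two compounds. Going by these compounds alone, the largest step so far, a number 40 percentage points lower from compound 2 to compound 4 (beyond the scatter) for 4-chlorophenyl in place of 3-fluorophenyl, changes the halogen and its place together, so it cannot be divided between the two.

Still open, as far as these compounds go, is whether 3-chlorophenyl would keep the high value seen with 3-fluorophenyl, and how a methoxy group or an amine would read on this aryl group. No evidence is at hand that would explain any of these steps.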